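Oxygen in the chain: compound 1 to compound 3

A few compounds are considered here, and "the series" means these few. Any claim that something is new, unique, unknown or untested is made for them only; others in the source may bear on it.

Going by the values given here, in a functional assay on cells (Homo sapiens) for inhibition, read by MTT assay, with a stated time of 48 h (a higher number here means a weaker inhibitor, a lower number a stronger inhibitor), compound 1 (`O=C(CCCOc1no[n+]([O-])c1S(=O)(=O)c1ccccc1)NO`) gives 22000 nM, the only number so far. For compound 2 (`O=C(CCCCCCOc1no[n+]([O-])c1S(=O)(=O)c1ccccc1)NO`) the entry reads "not determined" (no result reported), so no comparison between chains is available. Compound 3 (`O=C(COCCOc1no[n+]([O-])c1S(=O)(=O)c1ccccc1)NO`) keeps the core of compound 1 and changes the chain: (hydroxycarbamoyl)methoxy in place of (hydroxycarbamoyl)methyl on a saturated chain carbon, two bonds along the chain from an oxygen on an aromatic ring. Among the compounds with values here, no measured step bears on this change, so no shift beyond the scatter is expected, in either direction. The estimated step is a 1.1-fold lower number from compound 1 to compound 3 (0.04 log units; within the scatter). Compound 3 is expected at 20000 nM, with an estimated range of 7000 nM to 55000 nM.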

Compound 3, half-maximal inhibitory concentration: 19800 nM
Estimate against measurement, compound 3: 1.0-fold (0.00 log units) above; low and high end bracket the measured number.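

In this assay, (hydroxycarbamoyl)methoxy in place of (hydroxycarbamoyl)methyl on a saturated chain carbon, two bonds along the chain from an oxygen on an aromatic ring, gives a 1.1-fold lower number from compound 1 to compound 3 (0.05 log units; within the scatter). Going by these compounds alone, this is the first reading at this position, and the added chain oxygen brings no shift beyond the scatter. Nothing on hand offers an explanation for this result.

From the compounds shown here alone, how chain length bears on this read-out remains open. So does the effect of an amine in the chain, or of a carboxylic acid in place of the hydroxycarbamoyl end.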